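The source may hold more compounds than are shown below. What is called first, only, known or untested is meant among the compounds shown, and "the series" means these compounds.

For the measured compounds named here, in a functional assay on MCF7 cells (Homo sapiens) for inhibition, read by sulforhodamine B assay, with a stated time of 48 h (on this read-out lower numbers stand for stronger inhibition of growth and higher numbers for weaker inhibition of growth), compound 2 `N#CCC1=NN=C(c2ccc(Br)cc2)C(Br)O1` gives 70700 nM, the highest of the three numbers so far, while compound 3 `N#CCC1=NN=C(c2ccc([N+](=O)[O-])cc2)C(Br)O1` gives 10600 nM and compound 1 `N#CCC1=NN=C(c2ccc([N+](=O)[O-])cc2)CO1` gives 1 nM. Compound 4 `N#CCC1=NN=C(c2ccc(Br)cc2)CO1` has not yet been measured. It differs from compound 2 by hydrogen in place of bromo on a saturated ring carbon, which is hydrogen in place of bromo on a saturated ring carbon. The nearest guide is the same swap in reverse, bromo in place of hydrogen, which gave an 11000-fold higher number from compound 1 to compound 3 (4.03 log units; beyond the scatter). Nitro in place of bromo on an aromatic carbon gave a smaller change, a 6.7-fold lower number from compound 2 to compound 3 (0.82 log units; beyond the scatter). A large drop is therefore expected in this assay, though this rests on a single pair. The expected step is a 7100-fold lower number from compound 2 to compound 4 (3.85 log units; beyond the scatter). Compound 4 is estimated at 10 nM, with a range of 0.5 nM to 500 nM.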

Compound 4, concentration for 50% growth inhibition: 1500 nM
Compound 4: the middle estimate sits 150-fold (2.18 log units) below what was measured; measured number outside the range, above it.
By their numbers in this assay, from the lowest: compound 1; then compound 4; then compound 3; then compound 2.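

Hydrogen in place of bromo on the saturated ring carbon also lowers the number when the aromatic group carries bromo (a 47-fold lower number from compound 2 to compound 4 (1.67 log units; beyond the scatter)), so the direction seen with the nitro compounds holds on a second core, but its size does not carry over: the same change on two cores in this assay, an 11000-fold higher number (4.03 log units; beyond the scatter) from compound 1 to compound 3 and a 47-fold higher number (1.67 log units; beyond the scatter) from compound 4 to compound 2, 220-fold (2.35 log units) apart, beyond the scatter of two such steps. The aromatic change also depends on its surroundings, with bromo in place of nitro, when the saturated ring carbon carries hydrogen, giving a far larger step (a 1500-fold higher number from compound 1 to compound 4 (3.18 log units; beyond the scatter)) than it does when that carbon carries bromo: the same change on two cores in this assay, a 6.7-fold lower number (0.82 log units; beyond the scatter) from compound 2 to compound 3 and a 1500-fold lower number (3.18 log units; beyond the scatter) from compound 4 to compound 1, 220-fold (2.35 log units) apart, beyond the scatter of two such steps.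

The compounds shown leave open how a methyl or an amine on the saturated ring carbon would behave. They also leave open whether an amine or a methoxy on the aromatic carbon would fall nearer to bromo or to nitro.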